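The source may hold more compounds than are shown below. What is called first, only, known or untested is meant among the compounds shown, and "the series" means these compounds.

Working notes on three compounds sharing one core, with a fourth to be tested. In a functional assay on RAW264.7 cells (Mus musculus) for inhibition, read by ELISA, with a stated time of 24 h (on this read-out higher numbers stand for an effect only at larger amounts of compound and lower numbers for an effect already at smaller amounts), compound 1 `CC/C=C\C[C@H]1C(=O)C=C[C@H]1CC(=O)OCCO` gives 24000 nM, compound 2 `CC/C=C\C[C@H]1C(=O)C=C[C@H]1CC(=O)OCCOCCO` gives 36000 nM and compound 3 `CC/C=C\C[C@H]1C(=O)C=C[C@H]1CC(=O)OC(C)C` gives 20000 nM. On these numbers, compound 3 cannot be separated from the other two. The measured steps read a 1.2-fold lower number from compound 1 to compound 3 (0.08 log units; within the scatter) and a 1.8-fold lower number from compound 2 to compound 3 (0.26 log units; within the scatter).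

Compound 4 `CC/C=C\C[C@H]1C(=O)C=C[C@H]1CC(=O)OC(C)(C)C` turns isopropyl into tert-butyl, with methyl in place of hydrogen on a saturated chain carbon bound to an oxygen next to a carbonyl group and two saturated chain carbons.

Going by the values given here, no measured step is this exact change. The two steps above and a 1.5-fold higher number from compound 1 to compound 2 (0.18 log units; within the scatter) all alter the same side chain, and none leaves the scatter. A step beyond the scatter is therefore not expected in this assay, and no direction can be argued from these data. The expected step is a 1.1-fold higher number from compound 3 to compound 4 (0.04 log units; within the scatter). The estimate for compound 4 is 22000 nM, with an expected range from 11000 nM to 42000 nM.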

Compound 4, half-maximal effective concentration: 20000 nM
Compound 4: middle estimate off by 1.1-fold (0.04 log units), on the high side; the range from low to high includes it.
By their numbers in this assay, from the lowest: compounds 3, 4, 1 and 2 (each within the scatter of the next).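

In this assay there is no change at the digits printed from compound 3 to compound 4 (within the scatter), so methyl in place of hydrogen on this saturated chain carbon, a change at that carbon itself rather than a swap of the whole side chain, gives no separable difference. With a 1.8-fold lower number from compound 2 to compound 4 (0.26 log units; within the scatter) and a 1.2-fold lower number from compound 1 to compound 4 (0.08 log units; within the scatter) both within the scatter, tert-butyl also cannot be told apart from 2-(2-hydroxyethoxy)ethyl or 2-hydroxyethyl on this oxygen, so this range of side chains now includes one with no saturated chain carbon bearing hydrogen at that place. Nothing available bears on why this change leaves the number where it is.

On these data alone, all four compounds keep the ester, so it stays open whether a free carboxylic acid or an amide in its place would step beyond the scatter. Equally open, as far as these compounds go, is whether a phenyl ring or a longer chain on this oxygen would do so.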